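Swapping the amine ring on a dithiocarbamate phosphate

This account rests on a few compounds, and the source may have more. Where it says the series, first, only, none or still open, it means among the compounds named here.

The series studied here shares a core in which a dithiocarbamate is joined through a short linker to a phosphate bearing an alkyl chain. Compound 1 `CCCOP(=O)(O)OCCSC(=S)N1CCCC1` gives 67000 nM in a functional assay on MDA-MB-231 cells (Homo sapiens) for inhibition, read by MTT assay, with stated times of 18 h and 4 h; on this read-out higher numbers stand for weaker inhibition and lower numbers for stronger inhibition. Compound 2 `CCCCCCCCCCOP(=O)(O)OCCSC(=S)N1CCCC1` gives 67000 nM in this assay, so the step of no change at the digits printed from compound 1 to compound 2 (within the scatter) shows that lengthening the chain left the number where it was. Compound 3 `CCCCCCCCOP(=O)(O)OCCSC(=S)N1CCCCCC1` differs from compound 2 in both the chain and the amine ring; in this assay compound 3 gives 27000 nM. It stands furthest from compound 2, while compound 1 stands nearest. Compound 2 therefore sits level with compound 1 at the highest number of the three.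

Compound 4 `CCCCCCCCCCOP(=O)(O)OCCSC(=S)N1CCN(C)CC1` keeps the decyl chain of compound 2 and changes only the amine ring: 4-methylpiperazin-1-yl in place of pyrrolidin-1-yl on a thiocarbonyl carbon. For the measured compounds named here, no measured step isolates this change, and the only other ring variation, in compound 3, is confounded with the chain. Compound 4 is therefore expected to lie close to compound 2, a step of a 1.3-fold lower number from compound 2 to compound 4 (0.13 log units; within the scatter) in this assay. Compound 4 is estimated at 50000 nM, within 15000 nM to 150000 nM.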

Compound 4, half-maximal inhibitory concentration: 29000 nM
Compound 4: middle estimate off by 1.7-fold (0.24 log units), on the high side, within the range that was stated.
By their numbers in this assay, from the lowest: compounds 3 and 4 (each within the scatter of the next); then compounds 1 and 2 (each within the scatter of the next).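

For the compounds shown here, with the decyl chain held fixed, the amine ring on the thiocarbonyl carbon is read alone for the first time in this assay and the change to 4-methylpiperazin-1-yl gives a 2.3-fold lower number from compound 2 to compound 4 (0.36 log units; beyond the scatter) as a modest step beyond the scatter. The earlier compounds could not show this: the one listed step changed only the chain and moved nothing, while the different ring of compound 3 came with a different chain. The series therefore responds at this position where it did not respond to the chain, but nothing available bears on why this swap lowers the number.

As far as these compounds go, it remains open whether a piperidin-1-yl or morpholin-4-yl group on the same carbon would give a similar step. From the compounds shown here alone, it is also open whether the 4-methylpiperazin-1-yl step would hold on the propyl chain of compound 1.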